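Swapping One Amine for Another on a Urea

This account rests on a few compounds, and the source may have more. Where it says the series, first, only, none or still open, it means among the compounds named here.

Measured in an assay on a protein complex for displacement of a labelled ligand from CDK8/Cyclin C (Homo sapiens), read by TR-FRET, with a stated time of 1 h; on this read-out higher numbers stand for weaker inhibition and lower numbers for stronger inhibition:
Compound 1 `CNc1nccc(N2CC[C@H](NC(=O)Nc3ccc(CN(C)C)c(C(F)(F)F)c3)C2)n1`: 40.1 nM
Compound 2 `O=C(Nc1ccc(Cl)c(C(F)(F)F)c1)N[C@@H]1CCN(c2ccc3nncn3n2)C1`: 166 nM

Compound 1 has the lower of the two numbers, and its gap to compound 2 lies beyond the usual scatter. Among the compounds with values here, no pair of measured compounds differs in just one place, so no measured step is available. Compound 3 `CNc1nccc(N2CC[C@H](NC(=O)Nc3ccc(CN4CCC4)c(C(F)(F)F)c3)C2)n1` differs from compound 1 in one group only: azetidin-1-yl in place of dimethylamino on a saturated chain carbon bound to an aromatic carbon. Replacing dimethylamino with azetidin-1-yl is a small change, so the expected step of a 1.0-fold lower number from compound 1 to compound 3 (0.00 log units; within the scatter) is expected to stay within the scatter, in no clear direction. Compound 3 is therefore estimated at 40 nM, with a range from 15 nM to 110 nM.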

Compound 3, half-maximal inhibitory concentration in the CDK8/Cyclin C assay: 99.9 nM
Compound 3: middle estimate off by 2.5-fold (0.40 log units), on the low side, within the range that was stated.
By their numbers in the CDK8/Cyclin C assay, from the lowest: compound 1; then compounds 3 and 2 (each within the scatter of the next).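

In the CDK8/Cyclin C assay, this place on the urea's side chain proves sensitive to a small change: azetidin-1-yl in place of dimethylamino gives a 2.5-fold higher number from compound 1 to compound 3 (0.40 log units; beyond the scatter), so weaker inhibition. In a physicochemical assay for solubility, measured as kinetic solubility (a lower number here means a less soluble compound, a higher number a more soluble compound), compound 1 gives 102000 nM and compound 3 gives 84900 nM, two values within the scatter of each other, so the swap shows no measurable solubility difference here. Nothing measured explains the shift in inhibition. As far as these compounds go, whether pyrrolidin-1-yl, morpholin-4-yl or a primary amine at this place would match dimethylamino remains open.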